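From 2-bromoethoxy to 3-bromopropoxy

This account rests on a few compounds, and the source may have more. Where it says the series, first, only, none or still open, it means among the compounds named here.

Measured in a functional assay on MDA-MB-231 cells (Homo sapiens) for antiproliferative activity, read by MTT assay, with a stated time of 48 h; a lower number here means a stronger inhibitor, a higher number a weaker inhibitor:
Compound 1 `COc1ccc(N(C)c2ccnc(Cl)n2)cc1Cl` gives 1380 nM
Compound 2 `COc1ccc(N(C)c2ccnc(Cl)n2)cc1OCCBr` gives 6620 nM

Compound 2 holds the higher of the two numbers in this assay and is thus the weaker inhibitor. Compound 3 `COc1ccc(N(C)c2ccnc(Cl)n2)cc1OCCCBr` differs from it as follows: bromomethyl in place of bromo on a saturated chain carbon, two bonds along the chain from an oxygen on an aromatic ring, that is, 2-bromoethoxy to 3-bromopropoxy. Among the compounds with values here, no measured step covers this change directly. The only one available, a 4.8-fold higher number from compound 1 to compound 2 (0.68 log units; beyond the scatter), concerns a different replacement, so it gives only a loose guide to size. Little movement is therefore expected, with no firm direction. Compound 3 is expected at about 6000 nM, with an estimated range from 2500 nM to 14000 nM in this assay. The estimate means a 1.1-fold lower number from compound 2 to compound 3 (0.04 log units; within the scatter) as the expected step.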

Compound 3, half-maximal inhibitory concentration: 1280 nM
Compound 3: the middle estimate sits 4.7-fold (0.67 log units) above what was measured, and the stated range ends above it.
By their numbers in this assay, from the lowest: compounds 3 and 1 (each within the scatter of the next); then compound 2.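

In this assay, the added chain carbon matters at this position: going from 2-bromoethoxy to 3-bromopropoxy gives a 5.2-fold lower number from compound 2 to compound 3 (0.71 log units; beyond the scatter), so this site responds to chain length as well as to replacing the chloro. Replacing the chloro with 3-bromopropoxy gives a 1.1-fold lower number from compound 1 to compound 3 (0.03 log units; within the scatter), leaving the two groups level here, unlike 2-bromoethoxy. Nothing available explains this response to chain length.

With only two chain lengths shown, no trend can be drawn. From the compounds shown here alone, it remains open whether a longer chain would follow either value, and whether an amine or a hydroxyl in place of the terminal bromo would keep the number of compound 3.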